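Working notes: aryl change on the five-membered ring

The compounds below may be only part of what the source reports. "The series", "measured", "known", "first", "only" and "open" are said of these compounds alone.

The series shares one core, shown for compound 1 as `CC(C)(C)n1ncc(OCc2nnc(-c3ccccc3Cl)o2)c(Cl)c1=O` and for compound 2 as `Cc1cc(C)cc(-c2nnc(COc3cnn(C(C)(C)C)c(=O)c3Cl)o2)c1`. In a functional assay on the whole organism for inhibition, with Mythimna separata as the target, with a stated time of 5 days (a higher number here means that more compound is needed for the effect, a lower number that less compound is needed), compound 1 gives 61.2 ug/mL. For compound 2 the assay reports only a limit, > 300 ug/mL, so compound 2 stands at the edge of what this assay resolves, as noted in the limit of > 300 ug/mL in this assay, at which 1 of the 2 values shown sits. Within the data shown here, the one measured step, an at least 4.9-fold higher number from compound 1 to compound 2 (0.69 log units; beyond the scatter), goes from a halogen-bearing phenyl to a dimethyl-bearing phenyl and weakens the effect.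

Compound 3, `CC(C)(C)n1ncc(OCc2nnc(-c3cccc(F)c3)o2)c(Cl)c1=O`, differs from compound 2 by 3-fluorophenyl in place of 3,5-dimethylphenyl on an aromatic carbon. This change returns to a halogen-bearing phenyl, though not the same one as in compound 1, so the measured step bears on it only in part. Compound 3 is expected to need less compound than compound 2, with a step estimated as an at least 2.5-fold lower number from compound 2 to compound 3 (0.39 log units; beyond the scatter), since the halogen-bearing compound 1 gave 61.2 ug/mL. For compound 3 the estimate in this assay is 120 ug/mL, with a range from 40 ug/mL to 300 ug/mL.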

Compound 3, half-maximal effective concentration: 7.1 ug/mL
Estimate against measurement, compound 3: 17-fold (1.23 log units) above, and the stated range ends above it.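

At this position, on an aromatic carbon of the five-membered aromatic ring, the 3-fluorophenyl group gives the lowest number of the three compounds in this assay, with both of its steps beyond the scatter: an at least 42-fold lower number from compound 2 to compound 3 (1.62 log units; beyond the scatter), and an 8.6-fold lower number from compound 1 to compound 3 (0.94 log units; beyond the scatter). The first pair could be read as a simple contrast between a halogen-bearing and a dimethyl-bearing phenyl, but the second step separates two halogen-bearing phenyl groups, so carrying a halogen does not by itself set the number in this small set. Compound 2 has only a limit, so the step from it gives a bound and not a full size: the limit of > 300 ug/mL in this assay, at which 1 of the 3 values shown sits.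

The compounds shown cannot separate the kind of halogen from its place on the phenyl, since 2-chlorophenyl and 3-fluorophenyl differ in both. What 3-chlorophenyl, 2-fluorophenyl or an aminophenyl group would give at this position remains open, as does the cause of these steps.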